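A few compounds are considered here, and "the series" means these few. Any claim that something is new, unique, unknown or untested is made for them only; others in the source may bear on it.

Measured compounds in an assay on isolated protein for inhibition of protein kinase C epsilon type (Homo sapiens), read by coupled enzyme assay; a lower number here means a stronger inhibitor, a higher number a weaker inhibitor:
compound 1 `N#CC1(c2cc(CCO)cc(-c3ccnc4[nH]nc(C(F)(F)F)c34)c2)CC1`, 25 nM
compound 2 `N#CC1(c2cc(CC(O)C(F)(F)F)cc(-c3ccnc4[nH]nc(C(F)(F)F)c34)c2)CC1`, 267 nM
compound 3 `COCC(O)Cc1cc(-c2ccnc3[nH]nc(C(F)(F)F)c23)cc(C2(C#N)CC2)c1`, 77 nM

Compound 3 sits second highest of the three numbers in this assay: the smaller gap is a 3.1-fold higher number from compound 1 to compound 3 (0.49 log units; beyond the scatter), the larger gap is a 3.5-fold lower number from compound 2 to compound 3 (0.54 log units; beyond the scatter). The step to compound 4 `N#CC1(c2cc(CCF)cc(-c3ccnc4[nH]nc(C(F)(F)F)c34)c2)CC1` is fluoromethyl in place of 1-hydroxy-2-methoxyethyl on a saturated chain carbon bound to an aromatic carbon. Of the measured steps, a 3.1-fold higher number from compound 1 to compound 3 (0.49 log units; beyond the scatter) shows that the methoxymethyl added to compound 1 raised the number modestly, and an 11-fold higher number from compound 1 to compound 2 (1.03 log units; beyond the scatter) shows that a trifluoromethyl at that place raised it more. Within the data shown here, compound 4 differs from compound 1 only in fluorine for the hydroxyl on the chain, an exchange no measured step covers; compound 1 gives 25 nM. The expected step is therefore a 1.9-fold lower number from compound 3 to compound 4 (0.28 log units; within the scatter), a modest lowering. Compound 4 is estimated at 40 nM, range 12 nM to 130 nM.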

Compound 4, inhibition constant: 90 nM
Beside the measured number, compound 4's estimate is 2.3-fold (0.35 log units) below it, within the range that was stated.
By their numbers in this assay, from the lowest: compound 1; then compounds 3 and 4 (each within the scatter of the next); then compound 2.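

In this assay, among these compounds, fluoro in place of hydroxy on a saturated chain carbon, two bonds along the chain from an aromatic carbon, is a modest step upward (a 3.6-fold higher number from compound 1 to compound 4 (0.56 log units; beyond the scatter)), the first reading of a change to the hydroxy itself. Fluoromethyl and 1-hydroxy-2-methoxyethyl are not told apart (a 1.2-fold higher number from compound 3 to compound 4 (0.07 log units; within the scatter)), whereas fluoromethyl gives a lower number than 2,2,2-trifluoro-1-hydroxyethyl (a 3.0-fold lower number from compound 2 to compound 4 (0.47 log units; beyond the scatter)). No measured evidence accounts for these steps.

Open, on these data alone, is whether an amine or a methoxy in place of that hydroxy, or a longer chain ending in hydroxy, would match compound 1.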